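Ring-nitrogen substituent in an antiproliferative series: the phenyl case

The source may hold more compounds than are shown below. What is called first, only, known or untested is meant among the compounds shown, and "the series" means these compounds.

Measured in a functional assay on MCF7 cells (Homo sapiens) for antiproliferative activity, read by MTT assay, with a stated time of 48 h; a higher number here means a weaker inhibitor, a lower number a stronger inhibitor:
- compound 1 `COc1ccc(C2=N/C(=C\c3cc(Br)cc(Br)c3OC(C)=O)C(=O)NN2C(N)=S)cc1OC`: 13400 nM
- compound 2 `COc1ccc(C2=N/C(=C\c3cc(Br)cc(Br)c3OC(C)=O)C(=O)NN2c2ncc(-c3ccc(Br)cc3)s2)cc1OC`: 3280 nM

Compound 2 holds the lower of the two numbers, so it is the stronger inhibitor of this pair. Compound 3 `COc1ccc(C2=N/C(=C\c3cc(Br)cc(Br)c3OC(C)=O)C(=O)NN2c2ccccc2)cc1OC` is the next case, and its difference from compound 2 is a group of 6 heavy atoms (6 carbon; one six-membered aromatic ring of carbon only) in place of a group of 12 heavy atoms (9 carbon, 1 nitrogen, 1 sulfur, 1 bromine; one five-membered aromatic ring with 2 hetero atoms, one six-membered aromatic ring of carbon only), on an amine nitrogen in a ring. The phenyl that enters keeps a six-membered aromatic ring, while the five-membered aromatic ring and the bromine are lost.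

For the measured compounds named here, only one measured step bears on this place: a 4.1-fold lower number from compound 1 to compound 2 (0.61 log units; beyond the scatter). That step is modest, and it came with the larger group entering. Compound 3 carries a group of intermediate size, so part of that gain is expected to be given back in this assay. One step is thin evidence, and the data hold no earlier case of phenyl here. A modest move to a higher number is therefore expected, though no change beyond the scatter remains possible.

The expected change is a 1.8-fold higher number from compound 2 to compound 3 (0.26 log units; within the scatter).

For compound 3 the estimated value is 6000 nM, with an expected range of 2000 nM to 18000 nM.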

Compound 3, half-maximal inhibitory concentration: 5390 nM
Estimate against measurement, compound 3: 1.1-fold (0.05 log units) above; the measured number falls inside the stated range.
By their numbers in this assay, from the lowest: compounds 2 and 3 (each within the scatter of the next); then compound 1.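

In this assay, the phenyl in place of the larger group gives a 1.6-fold higher number from compound 2 to compound 3 (0.22 log units; within the scatter), which lies within the scatter, so the five-membered aromatic ring and the bromine add nothing that this assay can resolve at this amine nitrogen in a ring. Against the ring-free group of compound 1, the same phenyl gives a 2.5-fold lower number from compound 1 to compound 3 (0.40 log units; beyond the scatter), which lies beyond the scatter, so in this set a single six-membered aromatic ring of carbon only is enough for a modest gain, and the larger group is not required for it. No measured evidence accounts for the size of either step.

On these data alone, it remains open whether a ring is needed at all at this position, since a short alkyl chain or a cyclohexyl group on the same nitrogen would separate the effect of an aromatic ring from that of size alone. Also open, as far as these compounds go, is how far a phenyl carrying a single bromine, a methoxy group or a carboxylic acid would move the number in this assay relative to compound 3.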